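Series notes: amine side chain swap on a shared anilinopyrimidine core

The source may report more compounds than this note shows. Statements on the series, on what has been measured and on what is new or still open speak of the compounds shown alone.

Measured so far:
compound 1 `CC[S+]([O-])c1cc(F)ccc1Nc1nc(Nc2ccc(N(C)CCN(C)C)cc2OC)ncc1Cl`: 84.3 nM
compound 2 `CC[S+]([O-])c1cc(F)ccc1Nc1nc(Nc2ccc(N3CCCN(C)CC3)cc2OC)ncc1Cl`: 64.5 nM
compound 3 `CC[S+]([O-])c1ccccc1Nc1nc(Nc2ccc(N3CCCN(C)CC3)cc2OC)ncc1Cl`: 51.5 nM

All three were read in a functional assay on NCI-H2228 cells (Homo sapiens) for inhibition, read by CCK-8 assay; on this read-out lower numbers stand for stronger inhibition and higher numbers for weaker inhibition. Compound 3 gives the lowest number, but its neighbours sit close: the step of a 1.3-fold lower number from compound 2 to compound 3 (0.10 log units; within the scatter) and the step of a 1.3-fold higher number from compound 2 to compound 1 (0.12 log units; within the scatter) are both within the scatter, so no order among the three can be claimed.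

Compound 4 `CC[S+]([O-])c1ccccc1Nc1nc(Nc2ccc(N(C)CCN(C)C)cc2OC)ncc1Cl` has not been measured. It differs from compound 3 by (2-(dimethylamino)ethyl)(methyl)amino in place of 4-methyl-1,4-diazepan-1-yl on an aromatic carbon. The same change has already been made once, from compound 2 to compound 1, where it reads (2-(dimethylamino)ethyl)(methyl)amino in place of 4-methyl-1,4-diazepan-1-yl on an aromatic carbon and gave a 1.3-fold higher number from compound 2 to compound 1 (0.12 log units; within the scatter). The two cores on which the change is made differ by hydrogen in place of fluoro on an aromatic carbon; the place of the change is described in the same words in both cases, so it is taken as the same change.

Among the measured compounds shown here, on that basis the step of a 1.3-fold higher number from compound 3 to compound 4 (0.11 log units; within the scatter) is expected to be small, resting on the single earlier instance a 1.3-fold higher number from compound 2 to compound 1 (0.12 log units; within the scatter) from compound 2 to compound 1. Compound 4 is therefore estimated at 67 nM, with a range of 35 nM to 130 nM.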

Compound 4, half-maximal inhibitory concentration: 69.3 nM
Beside the measured number, compound 4's estimate is 1.0-fold (0.01 log units) below it; the range from low to high includes it.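

In this assay the swap of 4-methyl-1,4-diazepan-1-yl for (2-(dimethylamino)ethyl)(methyl)amino gives a 1.3-fold higher number from compound 3 to compound 4 (0.13 log units; within the scatter) and reads the same on both cores: the same change on two cores in this assay, a 1.3-fold higher number (0.12 log units; within the scatter) from compound 2 to compound 1 and a 1.3-fold higher number (0.13 log units; within the scatter) from compound 3 to compound 4, 1.0-fold (0.01 log units) apart, within the scatter of two such steps.
Hydrogen in place of fluoro gives a 1.2-fold lower number from compound 1 to compound 4 (0.09 log units; within the scatter) and likewise reads the same with either amine side chain: the same change on two cores in this assay, a 1.3-fold lower number (0.10 log units; within the scatter) from compound 2 to compound 3 and a 1.2-fold lower number (0.09 log units; within the scatter) from compound 1 to compound 4, 1.0-fold (0.01 log units) apart, within the scatter of two such steps.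
Across these four compounds, each change therefore carries from one core to the other without a visible difference, but every step lies within the scatter, so this shows only that neither change moves the number measurably here and does not show that a step of real size would carry over in the same way.

Open, on these data alone, is whether the same holds for other amines in this place, such as a morpholine, a piperazine or a longer chain between the two nitrogens. Also open, as far as these compounds go, is whether a group other than fluoro or hydrogen, such as chloro or methoxy, would move the number beyond the scatter and still carry across the two side chains.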